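From pyridin-4-yl to phenyl in compound 1

The source may hold more compounds than are shown below. What is called first, only, known or untested is meant among the compounds shown, and "the series" means these compounds.

Measured so far, all in an ADME assay on L02 cells (Homo sapiens) for antiproliferative activity, read by CCK-8 assay, with a stated time of 6 days; on this read-out lower numbers stand for stronger inhibition and higher numbers for weaker inhibition
- compound 1 `CCN(c1ccc(C#N)c(Cl)c1)c1cc(-c2ccncc2)ccc1C` gives 1730 nM
- compound 2 `N#Cc1ccc(N2CCc3cc(-c4cnc5ccccc5c4)ccc32)cc1C(F)(F)F` gives "not determined" (no result reported)

For the measured compounds named here, compound 1 (1730 nM) holds the only number so far. Compound 2 offers no number for comparison, so compound 1 cannot yet be called high or low within the series.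

The next compound to read is compound 3 `CCN(c1ccc(C#N)c(Cl)c1)c1cc(-c2ccccc2)ccc1C`, which keeps the core of compound 1 and changes one group: phenyl in place of pyridin-4-yl on an aromatic carbon. This puts phenyl in place of pyridin-4-yl on an aromatic carbon, meta to a large group and para to a methyl group.

Going by the values given here, no step between measured compounds is available, so this assay offers no direct precedent for this change. Among the compounds with values here, a modest move toward weaker inhibition is expected, not far beyond the usual scatter, though no measured pair supports that direction. The estimated step runs a 1.4-fold higher number from compound 1 to compound 3 (0.16 log units; within the scatter) and carries wide uncertainty. The expected value for compound 3 is 2500 nM with an estimated range from 800 nM to 8000 nM as the working figures.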

Compound 3, half-maximal inhibitory concentration: > 30000 nM
Compound 3 was reported as a limit (the forecaster's own chance of this, stated with the estimate: 15%); middle value at least 12-fold (1.07 log units) from the limit.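

On an aromatic carbon, meta to a large group and para to a methyl group, the aromatic ring is not interchangeable: with the core of compound 1 held fixed, phenyl in place of pyridin-4-yl gives an at least 17-fold higher number from compound 1 to compound 3 (1.23 log units; beyond the scatter) in this assay. For compound 3 the read-out is a limit and not a number: the limit of > 30000 nM in this assay, at which 1 of the 3 values shown sits.

The step is therefore a floor on the size of the change, and the two groups have the same count of heavy atoms, differing in the ring nitrogen and the hydrogen-bond acceptor counted for pyridin-4-yl, though nothing shown says why the number moves.

The compounds shown leave open whether the ring nitrogen alone accounts for the step, and whether its place in the ring counts, a question that pyridin-3-yl or pyrimidinyl at this carbon would address. Also open, on these data alone, is whether an amine or a carboxylic acid on the phenyl ring of compound 3 would bring the read-out back within the measurable range.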